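The source may report more compounds than this note shows. Statements on the series, on what has been measured and on what is new or still open speak of the compounds shown alone.

Compound 1 `O=S(=O)(c1ccc(F)c(Cl)c1)c1cnc2cc(F)ccc2c1-c1ccc(Cl)cc1` gives the highest of the three numbers in an ADME assay on microsomes from liver (Homo sapiens) for metabolic stability, tested at 2.5 uM (on this read-out lower numbers stand for slow clearance and higher numbers for fast clearance), at 0.39 mL/min. Compound 2 `O=S(=O)(c1cc(F)cc(F)c1)c1cnc2cc(F)ccc2c1-c1ccc(Cl)cc1` gives 0.03 mL/min in this assay, and compound 3 `O=S(=O)(c1ccc(F)c(F)c1)c1cnc2cc(F)ccc2c1-c1ccc(Cl)cc1` gives 0.01 mL/min. The measured steps concern the aryl on the sulfonyl sulfur: a 13-fold lower number from compound 1 to compound 2 (1.11 log units; beyond the scatter), a 39-fold lower number from compound 1 to compound 3 (1.59 log units; beyond the scatter) and a 3.0-fold lower number from compound 2 to compound 3 (0.48 log units; beyond the scatter). Compound 4 `O=S(=O)(c1ccc(F)c(Cl)c1)c1cnc2cc(F)ccc2c1-c1ccccc1F` differs from compound 1 at another place: 2-fluorophenyl in place of 4-chlorophenyl on an aromatic carbon. Among the compounds with values here, no measured step changes this aryl, so only a loose analogy exists, namely the lower number seen when fluoro replaced chloro in a 39-fold lower number from compound 1 to compound 3 (1.59 log units; beyond the scatter). Compound 4 is therefore expected to give a lower number, an estimated step of a 2.6-fold lower number from compound 1 to compound 4 (0.41 log units; beyond the scatter). For compound 4 this assay is estimated at 0.15 mL/min, within 0.03 mL/min to 0.6 mL/min.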

Compound 4, intrinsic clearance in a liver preparation (reported as CLH), per the amount of preparation that the assay uses: 1.07 mL/min
Estimate against measurement, compound 4: 7.1-fold (0.85 log units) below; measured number above the stated range.
By their numbers in this assay, from the lowest: compound 3; then compound 2; then compound 1; then compound 4.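

On the aromatic carbon opposite the ring nitrogen, the aryl also moves this assay: 2-fluorophenyl in place of 4-chlorophenyl gives a 2.7-fold higher number from compound 1 to compound 4 (0.44 log units; beyond the scatter). This is the only step shown that raises the number, and it shows that a change at this second place can outweigh nothing in the aryl on the sulfonyl sulfur only by being read on its own. No measurement given here accounts for its direction. The compounds shown leave open whether the rise follows the loss of the chloro group or the place of the fluoro group, as both change together. They also leave open how a methoxy group or an amine on this aryl would read.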